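This account rests on a few compounds, and the source may have more. Where it says the series, first, only, none or still open, it means among the compounds named here.

Going by the values given here, compound 3 (`CC(C(=O)NCc1ccc(C(C)(C)C)cc1N1CCCCC1)c1ccc(NS(C)(=O)=O)c(F)c1`) is one of three compounds measured in an assay on cells for antagonist activity at transient receptor potential cation channel subfamily V member 1 (Homo sapiens), read by FLIPR and calcium flux, with a stated time of 6 min; on this read-out higher numbers stand for weaker inhibition and lower numbers for stronger inhibition. Its value sits in the middle of the set: in this assay compound 3 gives 1.9 nM, compound 2 (`CC(C(=O)NCc1ccc(C(C)(C)C)nc1C1CCCCC1)c1ccc(NS(C)(=O)=O)c(F)c1`) gives 3.1 nM, and compound 1 (`CCC1CCN(c2nc(C(C)(C)C)ccc2CNC(=O)C(C)c2ccc(NS(C)(=O)=O)c(F)c2)CC1`) gives 0.1 nM. The two values of compound 3 and compound 2 lie within the scatter of each other, while the value of compound 1 stands clearly apart from both.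

Compound 4 (`CC(C)COc1cc(C(C)(C)C)ccc1CNC(=O)C(C)c1ccc(NS(C)(=O)=O)c(F)c1`) has not yet been measured. It differs from compound 3 in one place: isobutoxy in place of piperidin-1-yl on an aromatic carbon.

Among the compounds with values here, only one measured step offers a comparison, and it is an imperfect one. From compound 1 to compound 2 the group on the aromatic carbon changed from a nitrogen-linked ring to a carbon-linked ring, and the number moved by a 31-fold higher number from compound 1 to compound 2 (1.49 log units; beyond the scatter). The change to compound 4 also removes a nitrogen-linked ring, but what enters is a short oxygen-linked chain rather than a ring, so the measured step can only hint at the direction.

On this basis compound 4 is expected to give a somewhat higher number than compound 3, with the step estimated at a 3.2-fold higher number from compound 3 to compound 4 (0.50 log units; beyond the scatter). The value of compound 4 in this assay is therefore estimated at 6 nM, within a range from 2 nM to 20 nM.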

Compound 4, inhibition constant: 2.1 nM
Compound 4: the middle estimate sits 2.9-fold (0.46 log units) above what was measured; the measured number falls inside the stated range.
By their numbers in this assay, from the lowest: compound 1; then compounds 3, 4 and 2 (each within the scatter of the next).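

In this assay, putting isobutoxy in place of piperidin-1-yl, on an aromatic carbon ortho to a large group and meta to a tert-butyl group, gives a 1.1-fold higher number from compound 3 to compound 4 (0.04 log units; within the scatter). Going by these compounds alone, the one earlier step, a 31-fold higher number from compound 1 to compound 2 (1.49 log units; beyond the scatter), only put one ring in place of another, so it could not show whether a ring is needed here at all; this pair shows that, at least on this core, an oxygen-linked open chain with no ring reads the same as the nitrogen-linked ring. Nothing at hand explains why these two different groups give such similar numbers.

The compounds shown leave open whether a much shorter chain such as methoxy, or an open-chain amine such as dimethylamino, would also read the same at this position, and so how much variety the position accepts. They also leave open whether isobutoxy would hold up on the core of compound 1, since compound 1 gives 0.1 nM and carries 4-ethylpiperidin-1-yl rather than either group compared here.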